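The source may report more compounds than this note shows. Statements on the series, on what has been measured and on what is new or still open speak of the compounds shown alone.

Measured compounds:
Compound 1, `COc1ccc(-c2[nH]c3ccccc3c2/C=C(\C#N)S(=O)(=O)c2ccccc2)cc1`, in a functional assay on ACHN cells (Homo sapiens) for inhibition, read by sulforhodamine B assay, with a stated time of 48 h (on this read-out higher numbers stand for weaker inhibition of growth and lower numbers for stronger inhibition of growth), compound 1 gives 1900 nM.
Compound 2, `COc1ccc2[nH]c(-c3ccccc3)c(C=C(C#N)C#N)c2c1`, in this assay compound 2 gives 7400 nM.
Compound 3, `CC(=O)/C(=C\c1c(-c2ccccc2)[nH]c2ccccc12)S(=O)(=O)c1ccccc1`, in this assay compound 3 gives 1800 nM.

All three compounds share a core in which a vinyl arm carries a nitrile or a sulfonyl group. Compound 3 has the lowest number of the three in this assay. Against compound 1 its value differs by so little that the two cannot be told apart within the usual scatter of this measurement. Against compound 2 the gap is clearly beyond that scatter, so compound 3 inhibits growth more strongly than compound 2.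

Compound 4, `O=C(/C(=C\c1c(-c2ccccc2)[nH]c2ccccc12)S(=O)(=O)c1ccccc1)c1ccccc1`, is not yet measured. It differs from compound 3 in one place: phenyl in place of methyl on a carbonyl carbon. Among the measured compounds shown here, no measured pair in this set shows what such an exchange does in this assay, so there is no step to lean on. With the sulfonyl arm kept, as in compound 3, the expectation is for a value near that of compound 3 and for a step, from compound 3 to compound 4, of a 1.1-fold lower number from compound 3 to compound 4 (0.05 log units; within the scatter), not beyond the scatter in either direction. Compound 4 is therefore estimated at 1600 nM, with a range from 500 nM to 5000 nM.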

Compound 4, concentration for 50% growth inhibition: 6700 nM
Estimate against measurement, compound 4: 4.2-fold (0.62 log units) below; the whole stated range lies below it.
By their numbers in this assay, from the lowest: compounds 3 and 1 (each within the scatter of the next); then compounds 4 and 2 (each within the scatter of the next).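

Among the compounds shown here, until now, no two compounds in this set differed in only one place, so nothing showed how much this position matters in this assay. The exchange of acetyl for benzoyl gives a 3.7-fold higher number from compound 3 to compound 4 (0.57 log units; beyond the scatter), which shows that the group on this carbonyl carbon is not a free choice: with the rest of the molecule unchanged, phenyl in place of methyl weakens inhibition of growth by more than the usual scatter. No supporting measurement is available to explain the step, so the data record its size but not its origin.

This is a single pair, and it marks only two points at one position, so it leaves open whether an ethyl group or a longer chain on the same carbonyl carbon would stay close to methyl or fall nearer to phenyl. Also open, going by these compounds, is whether a phenyl ring carrying a methoxy group, or an amine on that carbon, would change the reading, and whether the same exchange would give a similar step on a different core.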